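The source may hold more compounds than are shown below. What is called first, only, known or untested is meant among the compounds shown, and "the series" means these compounds.

Measured so far in an in vitro assay on 293-EBNA cells for binding affinity to corticotropin-releasing factor receptor 1 (Homo sapiens); a higher number here means a weaker inhibitor, a lower number a stronger inhibitor:
compound 1, `COCCNc1nc(C)nc2c1ncn2-c1ccc(C(C)C)cc1Br`: 210 nM
compound 2, `CCCC(CC)Nc1nc(C)nc2c1ncn2-c1ccc(C(C)C)cc1Br`: 4.4 nM

Compound 2 gives the lower of the two numbers; the step from the first to the second, a 48-fold lower number from compound 1 to compound 2 (1.68 log units; beyond the scatter), is large and beyond the scatter. Compound 3, `CCCC(CCC)Nc1nc(C)nc2c1ncn2-c1ccc(C(C)C)cc1Br`, differs from compound 2 by methyl in place of hydrogen on a saturated chain carbon, three bonds along the chain from a nitrogen on an aromatic ring. Within the data shown here, no measured step adds a single methyl in this way; the only step available swaps the whole chain, so it bears on compound 3 at most indirectly. A change of no more than the scatter is therefore expected, a 1.0-fold higher number from compound 2 to compound 3 (0.01 log units; within the scatter). For compound 3 the estimate in this assay is 4.5 nM, within 1.5 nM to 13 nM.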

Compound 3, inhibition constant: 3.6 nM
The estimate for compound 3 lay 1.3-fold (0.10 log units) above the measured number; measured number inside the range.
By their numbers in this assay, from the lowest: compounds 3 and 2 (each within the scatter of the next); then compound 1.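

In this assay, methyl in place of hydrogen on a saturated chain carbon, three bonds along the chain from a nitrogen on an aromatic ring, gives a 1.2-fold lower number from compound 2 to compound 3 (0.09 log units; within the scatter), so this change does not separate 1-ethylbutyl from 1-propylbutyl. With 1-propylbutyl in place of 2-methoxyethyl, the large step remains: a 58-fold lower number from compound 1 to compound 3 (1.77 log units; beyond the scatter). No evidence bears on the reason for either step. Still open, on these data alone, is how a longer branched chain such as 1-butylpentyl, a cyclopentyl ring or a chain carrying an amine would read on this nitrogen.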